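Swapping Trifluoromethyl for 1,3-Oxazol-4-yl on a Carbonyl

The source may report more compounds than this note shows. Statements on the series, on what has been measured and on what is new or still open speak of the compounds shown alone.

Compound 1, `O=C(C1CCN(C(=O)C(F)(F)F)CC1)N1N=CCC1c1ccccc1`: > 1.5 h
Compound 2, `CC(C)(C)C(=O)N1N=CCC1c1ccc(Cl)cc1`: 0.433 h

In an ADME assay on microsomes (Homo sapiens) for metabolic stability (a higher number here means that the compound lasts longer, a lower number that the compound disappears faster), compound 1 reaches > 1.5 h, which is a limit of the assay rather than a number. Compound 2 gives 0.433 h. These two compounds differ in more than one place, so their values stand side by side without a step between them. Compound 3, `O=C(c1cocn1)N1CCC(C(=O)N2N=CCC2c2ccccc2)CC1`, has not been measured yet. It differs from compound 1 by 1,3-oxazol-4-yl in place of trifluoromethyl on a carbonyl carbon. The exchange sits on a carbonyl carbon whose other neighbours are an amide-type nitrogen in a ring. Among the compounds with values here, no measured step in this assay shows what such a change does, and compound 1 itself is known only as the limit of > 1.5 h in this assay, at which 1 of the 2 values shown sits. The step of a number no higher from compound 1 to compound 3 (the limit leaves the size open) is therefore expected to be small, within the scatter, in either direction. Compound 3 is estimated at 1.5 h, with a range from 0.5 h to 4 h.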

Compound 3, half-life: > 2.75 h
Compound 3 gave a limit, no number; the forecaster's own chance of this, stated with the estimate: 40%; at least 1.8-fold (0.26 log units) between middle value and limit.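

In this assay compound 3 gives > 2.75 h, which is a limit and not a number. Within the data shown here, compound 1 also stands at a limit, so no step from compound 1 to compound 3 can be read. The compounds shown leave open whether 1,3-oxazol-4-yl in place of trifluoromethyl changes the half-life at all.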